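Aryl swap on the ring nitrogen: compound 3 to compound 4

The source may hold more compounds than are shown below. What is called first, only, known or untested is meant among the compounds shown, and "the series" means these compounds.

Three compounds share one core and differ only in the group on the amine nitrogen in the ring. In a functional assay on HEK293 cells with D(4) dopamine receptor (Homo sapiens) as the target, read by FLIPR (a higher number here means a larger maximal response, a lower number a smaller maximal response), compound 1 `CCO/N=C(\CCN1CCN(c2ccccc2C#N)CC1)c1ccccc1` gives 82%, compound 2 `CCO/N=C(\CCN1CCN(c2cccc(OC)c2)CC1)c1ccccc1` gives 30%, and compound 3 `CCO/N=C(\CCN1CCN(c2ccc(OC)cc2)CC1)c1ccccc1` gives 5%, the lowest of the three, with the steps of a number 77 percentage points lower from compound 1 to compound 3 (beyond the scatter) and a number 25 percentage points lower from compound 2 to compound 3 (beyond the scatter) both beyond the scatter. Compound 4 `CCO/N=C(\CCN1CCN(c2ncccn2)CC1)c1ccccc1` is not yet measured. It differs from compound 3 by pyrimidin-2-yl in place of 4-methoxyphenyl on an amine nitrogen in a ring. The steps of a number 52 percentage points lower from compound 1 to compound 2 (beyond the scatter), a number 77 percentage points lower from compound 1 to compound 3 (beyond the scatter) and a number 25 percentage points lower from compound 2 to compound 3 (beyond the scatter) show that this position moves the response strongly, but none of them exchanges a methoxyphenyl for pyrimidin-2-yl, so the direction is uncertain. The expected step of a number 30 percentage points higher from compound 3 to compound 4 (beyond the scatter) is a modest rise with wide uncertainty. The estimate for compound 4 is 35%, within 5% to 70%.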

Compound 4, largest response reached (reported as efficacy), in percent of the reference or control that the assay uses: 26%
Compound 4: middle estimate off by 9 percentage points, on the high side, and the stated range covers the measured number.
By their numbers in this assay, from the lowest: compound 3; then compounds 4 and 2 (each within the scatter of the next); then compound 1.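

In this assay, the amine nitrogen in the ring also carries a response with an aromatic ring holding 2 hetero atoms, not only with substituted phenyl groups. Pyrimidin-2-yl gives a number 21 percentage points higher from compound 3 to compound 4 (beyond the scatter) and a number 4 percentage points lower from compound 2 to compound 4 (within the scatter), which places it level with 3-methoxyphenyl, while a number 56 percentage points lower from compound 1 to compound 4 (beyond the scatter) leaves it well under 2-cyanophenyl. Nothing measured here explains these steps. Whether the ring nitrogens of pyrimidin-2-yl or the loss of the methoxy group accounts for the change from 4-methoxyphenyl stays open. Plain phenyl and pyridin-2-yl on the same nitrogen would separate these two changes.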